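Flipping One Ring Centre on the Cyclopropane Amide

A few compounds are considered here, and "the series" means these few. Any claim that something is new, unique, unknown or untested is made for them only; others in the source may bear on it.

Compound 2 `C[C@@H]1C[C@@H]1C(=O)N1CC2CC(C1)N2` has the lowest number of the two compounds measured in an assay on CHO cells for displacement of a labelled ligand from Neuronal acetylcholine receptor; alpha3/alpha6/beta2/beta3 (Homo sapiens), read by scintillation counting; a lower number here means a stronger inhibitor, a higher number a weaker inhibitor: compound 2 gives 92 nM, while compound 1 `CC(C)C(=O)N1CC2CC(C1)N2` gives 580 nM. For the measured compounds named here, the only measured step, a 6.3-fold lower number from compound 1 to compound 2 (0.80 log units; beyond the scatter), came from exchanging the isopropyl group for the methyl-bearing three-membered ring on the carbonyl carbon. Compound 3 `C[C@@H]1C[C@H]1C(=O)N1CC2CC(C1)N2` keeps every atom and bond of compound 2; (the two compounds have the same atoms and bonds; at least one stereo element is drawn with a configuration in one of them and without one in the other: 1 of 4 stereo elements differ; a stereocentre at a saturated ring carbon is drawn S in compound 2 and R in compound 3). Going by the values given here, no measured step shows what such a change of handedness at one ring carbon does here, so the direction is not predictable from these numbers, though the step from compound 1 to compound 2 shows that this ring does matter to this assay. The number for compound 3 is therefore expected to stay within a broad band around compound 2, with a somewhat weaker outcome as the estimate: a 2.0-fold higher number from compound 2 to compound 3 (0.29 log units; within the scatter). Compound 3 is estimated at 180 nM, between 50 nM and 700 nM.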

Compound 3, inhibition constant: 14 nM
For compound 3 the middle estimate is 13-fold (1.11 log units) above the measured one; measured number outside the range, below it.
By their numbers in this assay, from the lowest: compound 3; then compound 2; then compound 1.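

With no atom or bond changed, a different handedness at one ring carbon alone gives a 6.6-fold lower number from compound 2 to compound 3 (0.82 log units; beyond the scatter) in this assay, so the arrangement of the ring in space counts here, and not just the presence of the ring. The full exchange of isopropyl for 2-methylcyclopropyl on the carbonyl carbon can therefore reach a 41-fold lower number from compound 1 to compound 3 (1.62 log units; beyond the scatter), and how much it gains depends on the handedness drawn at that ring carbon. One caution applies when reading the change of handedness: the fact that one of compounds 2 and 3 is drawn with a defined configuration and the other without, at the place where they differ

Going by these compounds, it remains open how much of the gain needs the methyl group at all, and whether an ethyl group in its place, or a plain cyclopropyl, would hold the number as low. On these data alone, the effect of reversing the handedness at the other ring carbon also remains open.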